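The source may report more compounds than this note shows. Statements on the series, on what has been measured and on what is new or still open speak of the compounds shown alone.

Working notes on the series. Among the compounds with values here, compound 3 `O=C(CCC1CCCCC1)OCCc1c(-c2ccccc2Cl)c2cc(Cl)ccc2[nH]c1=O` gives 160000 nM in an ADME assay on HepG2 2.2.15 cells (Homo sapiens) for cytotoxicity (a higher number here means that more compound is tolerated, a lower number that less compound is tolerated), the lowest of the three numbers so far. Compound 1 `O=c1[nH]c2ccc(Cl)cc2c(-c2ccccc2Cl)c1CCO` gives 380000 nM in this assay, and compound 2 `CCCCC(=O)OCCc1c(-c2ccccc2Cl)c2cc(Cl)ccc2[nH]c1=O` gives 200000 nM. The step of a 2.4-fold lower number from compound 1 to compound 3 (0.38 log units; beyond the scatter) is the only one beyond the scatter; the steps of a 1.9-fold lower number from compound 1 to compound 2 (0.28 log units; within the scatter) and a 1.3-fold lower number from compound 2 to compound 3 (0.10 log units; within the scatter) are not. Compound 4 `O=C(/C=C/c1cccc(C(F)(F)F)c1)OCCc1c(-c2ccccc2Cl)c2cc(Cl)ccc2[nH]c1=O` is not yet measured. Its change from compound 3 is 2-(3-(trifluoromethyl)phenyl)ethenyl in place of 2-cyclohexylethyl on a carbonyl carbon. Within the data shown here, the steps that bear on it are those in which the ester part was varied, namely a 2.4-fold lower number from compound 1 to compound 3 (0.38 log units; beyond the scatter) and a 1.3-fold lower number from compound 2 to compound 3 (0.10 log units; within the scatter): both esters sit close to one another, and only the step from the free alcohol to the larger ester reached beyond the scatter. For compound 4 a step of roughly a 1.3-fold lower number from compound 3 to compound 4 (0.12 log units; within the scatter) is therefore expected, that is, a number near that of compound 3 or somewhat lower. The estimate for compound 4 is 120000 nM, with a range from 50000 nM to 300000 nM.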

Compound 4, half-maximal cytotoxic concentration: > 1400000 nM
Compound 4 ended at the assay's limit; the forecaster's own chance of this, stated with the estimate: 10%; at least 11-fold (1.06 log units) between middle value and limit.
By their numbers in this assay, from the lowest: compounds 3, 2 and 1 (each within the scatter of the next, the first and the last beyond it). At a limit, above all of these: compound 4.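

In this assay compound 4 stands at a limit and not at a number: the limit of > 1400000 nM in this assay, at which 1 of the 4 values shown sits. The group on this carbonyl carbon is not indifferent to the read-out: 2-(3-(trifluoromethyl)phenyl)ethenyl in place of 2-cyclohexylethyl gives an at least 8.7-fold higher number from compound 3 to compound 4 (0.94 log units; beyond the scatter), and in place of butyl it gives an at least 7.0-fold higher number from compound 2 to compound 4 (0.84 log units; beyond the scatter). The two saturated groups had shown no such separation, with a 1.3-fold lower number from compound 2 to compound 3 (0.10 log units; within the scatter), so the earlier esters gave no sign that a change at this place could produce a step of this size.

The compounds shown do not separate the roles of the aromatic ring, the double bond and the trifluoromethyl group in this step. As far as these compounds go, whether a chain ending in an amine or a carboxylic acid at this place would shift the number in the same direction also remains open.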